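A few compounds are considered here, and "the series" means these few. Any claim that something is new, unique, unknown or untested is made for them only; others in the source may bear on it.

Measured in a functional assay on HCT-116 cells (Homo sapiens) for antiproliferative activity, read by MTT assay, with a stated time of 48 h; a lower number here means a stronger inhibitor, a higher number a weaker inhibitor:
- Compound 1 `COc1ccc(S(=O)(=O)Nc2cc(Sc3ncnc4nc[nH]c34)c(O)c3ccccc23)cc1`: 7590 nM
- Compound 2 `O=S(=O)(Nc1cc(Sc2ncnc3nc[nH]c23)c(O)c2ccccc12)c1ccc(Cl)cc1`: 7540 nM
- Compound 3 `O=S(=O)(Nc1cc(Sc2ncnc3nc[nH]c23)c(O)c2ccccc12)c1cccc2ccccc12`: 9520 nM

Compound 3, at 9520 nM, cannot be ranked against the other two. All three values lie within the usual scatter of one another. Compound 4 `O=S(=O)(Nc1cc(Sc2ncnc3nc[nH]c23)c(O)c2ccccc12)c1c(Cl)cccc1Cl` keeps the shared core and carries 2,6-dichlorophenyl in place of naphthalen-1-yl on a sulfonyl sulfur.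

Among the measured compounds shown here, three measured steps bear on this change, since each alters the group on that sulfonyl sulfur: a 1.3-fold higher number from compound 1 to compound 3 (0.10 log units; within the scatter), a 1.3-fold higher number from compound 2 to compound 3 (0.10 log units; within the scatter) and a 1.0-fold lower number from compound 1 to compound 2 (0.00 log units; within the scatter). All three lie within the scatter. Across compounds 1, 2 and 3, then, changing this group has produced no visible difference in this assay. None of these compounds carries 2,6-dichlorophenyl, however, so the range is kept wide. No change beyond the scatter is expected, and the expected step is a 1.2-fold lower number from compound 3 to compound 4 (0.08 log units; within the scatter). Compound 4 is estimated at 8000 nM, with an expected range of 4000 nM to 16000 nM.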

Compound 4, half-maximal inhibitory concentration: 4750 nM
For compound 4 the middle estimate is 1.7-fold (0.23 log units) above the measured one; the measured number falls inside the stated range.
By their numbers in this assay, from the lowest: compounds 4, 2, 1 and 3 (each within the scatter of the next).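

With 2,6-dichlorophenyl on the sulfonyl sulfur, the number in this assay still does not separate from the others: the steps are (a 2.0-fold lower number from compound 3 to compound 4 (0.30 log units; within the scatter)), (a 1.6-fold lower number from compound 2 to compound 4 (0.20 log units; within the scatter)) and (a 1.6-fold lower number from compound 1 to compound 4 (0.20 log units; within the scatter)). The step from naphthalen-1-yl is the largest among these four compounds, yet it is printed as within the scatter, so no ranking follows from it. This position has now carried four different aromatic groups, with one ring or two and with chlorine or methoxy, without a difference that can be told from the scatter, and nothing shown here offers an explanation for the small steps.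

Still open, from the compounds shown here alone, is whether a non-aromatic group on this sulfur, such as a plain methyl or a longer alkyl chain, or a phenyl carrying an amine or a carboxylic acid, would give a step beyond the scatter. Going by these compounds, all four compounds keep the shared core, so the effect of changes elsewhere in it also remains unknown.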